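A few compounds are considered here, and "the series" means these few. Any claim that something is new, unique, unknown or untested is made for them only; others in the source may bear on it.

Compound 1 `O=C1C2CCCCN2C(=O)N1CN1CCN(c2ccccc2)CC1` in an assay on isolated protein for binding affinity to Adrenergic receptor alpha-1 (Rattus norvegicus), read by radioligand binding (a lower number here means a stronger inhibitor, a higher number a weaker inhibitor), gives > 1000 nM. That entry for compound 1 is a limit of the assay, not a number. Compound 2 `O=C1C2CCCCN2C(=O)N1CCCN1CCN(c2ccccc2)CC1` gives 11.4 nM in this assay. Compound 3 `COc1ccccc1N1CCN(CCCN2C(=O)C3CCCCN3C2=O)CC1` gives 9.9 nM in this assay.

Of the two numbers shown, the one for compound 3 is the lower, but its nearest neighbour is compound 2, and the step between them, a 1.2-fold lower number from compound 2 to compound 3 (0.06 log units; within the scatter), lies within the scatter, so the two cannot be told apart. Within the data shown here, that step, methoxy in place of hydrogen on an aromatic carbon, is the only measured change on the ring that sits on the amine nitrogen, and it barely moved the number.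

Compound 4 `O=C1C2CCCCN2C(=O)N1CCCN1CCN(c2cccc(Cl)c2)CC1` has not yet been measured. It differs from compound 3 by 3-chlorophenyl in place of 2-methoxyphenyl on an amine nitrogen in a ring. Among the measured compounds shown here, one part of this change removes the methoxy whose arrival was measured as within the scatter; the other part, the chlorine of the entering 3-chlorophenyl, has no counterpart among the measured compounds. The expected step in this assay is therefore a 1.2-fold higher number from compound 3 to compound 4 (0.08 log units; within the scatter), with no firm direction. Compound 4 is estimated at 12 nM, within a range from 4 nM to 40 nM.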

Compound 4, inhibition constant: 17.9 nM
Estimate against measurement, compound 4: 1.5-fold (0.17 log units) below, and the stated range covers the measured number.
By their numbers in this assay, from the lowest: compounds 3, 2 and 4 (each within the scatter of the next). At a limit, above all of these: compound 1.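

In this assay, replacing the whole aryl group on the amine nitrogen gives a 1.8-fold higher number from compound 3 to compound 4 (0.26 log units; within the scatter), and adding a chlorine to the plain phenyl gives a 1.6-fold higher number from compound 2 to compound 4 (0.20 log units; within the scatter). Among these compounds, until now, methoxy was the only group tried on this ring; these steps add a second group, a chlorine, carried as 3-chlorophenyl, and compounds 2, 3 and 4 still cannot be told apart, since each step among them lies within the scatter. So at this position, three different aryl groups (plain phenyl, 2-methoxyphenyl and 3-chlorophenyl) give numbers that this assay does not separate, and nothing shown here gives a measured reason for that.

The compounds shown leave open whether any group on this ring would move the number beyond the scatter, for example a carboxylic acid, a primary amine, or a chlorine in the form of 2-chlorophenyl or 4-chlorophenyl. They also leave open whether the same aryl groups would stay indistinguishable on a longer chain, and whether they would do so at any receptor other than this one.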